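The source may hold more compounds than are shown below. What is called first, only, known or untested is meant among the compounds shown, and "the series" means these compounds.

Four compounds with a shared core are described here. Compound 1 `CSc1cc(C(=O)N2CCc3ccccc32)cc(C#N)c1O` and compound 2 `N#Cc1cc(C(=O)N2CCc3ccccc32)cc(C(F)(F)F)c1O` carry one core; compound 3 `O=C(c1cc(Cl)c(O)c(C(F)(F)F)c1)N1CS(=O)(=O)c2ccccc21` and compound 4 `CSc1cc(C(=O)N2CS(=O)(=O)c3ccccc32)cc(Cl)c1O` carry another, and the difference between the two cores is not broken down here.

In an assay on tissue (RPTEC cells) for inhibition of solute carrier family 22 member 12 (Homo sapiens), read by scintillation counting, with stated times of 15 min and 2 h (on this read-out higher numbers stand for weaker inhibition and lower numbers for stronger inhibition), compound 1 gives > 100000 nM, which is a limit of the assay and not a number. In this assay compound 2 gives > 100000 nM, likewise a limit. For the measured compounds named here, compound 3 gives 2600 nM in this assay, the only number among the three values.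

The change from compound 2 to compound 1 is methylsulfanyl in place of trifluoromethyl on an aromatic carbon; its step in this assay is a step that the two limits leave unreadable from compound 2 to compound 1, because of the limit of > 100000 nM in this assay, at which 2 of the 3 values shown sit. The change from compound 3 to compound 4 is methylsulfanyl in place of trifluoromethyl on an aromatic carbon, the same kind of change, differing in that it sits meta to a chloro group rather than meta to a cyano group.

Going by the values given here, since the only measured instance of this change is unreadable, the expected step from compound 3 to compound 4 in this assay is taken as a 2.3-fold higher number from compound 3 to compound 4 (0.36 log units; beyond the scatter), resting on compound 3 at 2600 nM with wide uncertainty. Compound 4 is therefore estimated at 6000 nM, between 1200 nM and 40000 nM.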

Compound 4, half-maximal inhibitory concentration: 5700 nM
Compound 4: middle estimate off by 1.1-fold (0.02 log units), on the high side; the range from low to high includes it.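

In this assay, placing methylsulfanyl where trifluoromethyl stood gives a 2.2-fold higher number from compound 3 to compound 4 (0.34 log units; beyond the scatter), so in the core of compound 3 this change has a modest, readable effect. The same change in the other core cannot be read, because both of its values are limits: the limit of > 100000 nM in this assay, at which 2 of the 4 values shown sit. This leaves a single readable instance, which describes one pair carrying a chloro group and does not show that the step carries over to the core of compound 1, where the pair also carries a nitrile.

The compounds shown leave open how an amine or a carboxylic acid would read on this aromatic carbon, ortho to a hydroxy group, and whether a longer chain such as ethylsulfanyl would move the number in the same direction as methylsulfanyl. They also leave open whether the step would hold in the core of compound 3 with a nitrile in place of the chloro group.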